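The source may report more compounds than this note shows. Statements on the series, on what has been measured and on what is new or still open speak of the compounds shown alone.

Compounds measured in a functional assay on Jurkat cells (Homo sapiens) for inhibition; a lower number here means a stronger inhibitor, a higher number a weaker inhibitor:

Compound 1 `C[C@H](NC(=O)C(=O)Nc1ccccc1F)C(=O)N[C@@H](CC(=O)O)C(=O)COc1c(F)c(F)cc(F)c1F` gives 160 nM.
Compound 2 `C[C@H](NC(=O)C(=O)Nc1ccccc1C(F)(F)F)C(=O)N[C@@H](CC(=O)O)C(=O)COc1c(F)c(F)cc(F)c1F` gives 61 nM.
Compound 3 `C[C@H](NC(=O)C(=O)Nc1ccccc1-c1ccc[nH]1)C(=O)N[C@@H](CC(=O)O)C(=O)COc1c(F)c(F)cc(F)c1F` gives 56 nM.

Compound 3 has the lowest number of the three, but its nearest neighbour, compound 2, sits within the scatter of it, so the two cannot be ranked against each other. Only compound 1 lies clearly apart: the step of a 2.9-fold lower number from compound 1 to compound 3 (0.46 log units; beyond the scatter) is beyond the scatter, as is the step of a 2.6-fold lower number from compound 1 to compound 2 (0.42 log units; beyond the scatter). The step of a 1.1-fold lower number from compound 2 to compound 3 (0.04 log units; within the scatter) is within the scatter.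

Compound 4 `C[C@H](NC(=O)C(=O)Nc1ccccc1Cc1ccccc1)C(=O)N[C@@H](CC(=O)O)C(=O)COc1c(F)c(F)cc(F)c1F` differs from compound 3 in one place: benzyl in place of 1H-pyrrol-2-yl on an aromatic carbon. The place is on an aromatic carbon of a six-membered aromatic ring of carbon only, ortho to a large group.

Among the measured compounds shown here, two measured steps bear on this change. Both replacements of fluoro by a larger group at this position, trifluoromethyl in compound 2 and 1H-pyrrol-2-yl in compound 3, gave a modest gain over compound 1, while the exchange of one larger group for another, from compound 2 to compound 3, stayed within the scatter. Benzyl is a third larger group at the same position, so the step of a 1.1-fold higher number from compound 3 to compound 4 (0.03 log units; within the scatter) is expected to stay within the scatter. Compound 4 is therefore estimated at 60 nM in this assay, with a range from 25 nM to 150 nM.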

Compound 4, half-maximal inhibitory concentration: 10 nM
Beside the measured number, compound 4's estimate is 6.0-fold (0.78 log units) above it; measured number outside the range, below it.
By their numbers in this assay, from the lowest: compound 4; then compounds 3 and 2 (each within the scatter of the next); then compound 1.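

In this assay, larger groups at this position are not interchangeable: trifluoromethyl and 1H-pyrrol-2-yl could not be told apart, yet benzyl stands clear of both, with a 5.6-fold lower number from compound 3 to compound 4 (0.75 log units; beyond the scatter) and a 6.1-fold lower number from compound 2 to compound 4 (0.79 log units; beyond the scatter). Among the compounds shown here, measured against the fluoro group, the change gives a 16-fold lower number from compound 1 to compound 4 (1.20 log units; beyond the scatter), the only step in this set rated large, so the values of compound 2 and compound 3 did not mark the limit of what a change at this position can give. Benzyl has 7 heavy atoms, all carbon, and 0 hydrogen-bond donors, whereas the 1H-pyrrol-2-yl group it replaces has 5 heavy atoms and 1 hydrogen-bond donor, so a gain at this position does not depend on keeping that donor.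

No measurement available here accounts for the gain. Going by these compounds, it remains open whether the gain belongs to the six-membered ring that benzyl brings or to the carbon that links this ring, a question that phenyl, a longer phenethyl chain, or a benzyl ring carrying an amine or a carboxylic acid could help to settle.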